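Replacing 2-fluorophenyl with 2-phenylethenyl in compound 3

The source may hold more compounds than are shown below. What is called first, only, known or untested is meant among the compounds shown, and "the series" means these compounds.

- compound 1 `Nc1sc2c(c1-c1nc3cc(Cl)ccc3s1)CCCC2`: 93.7 ug/mL
- compound 2 `Clc1ccc(/C=N/c2sc3c(c2-c2nc4ccccc4s2)CCC3)cc1`: 431 ug/mL
- compound 3 `Fc1ccccc1/C=N/c1sc2c(c1-c1nc3ccccc3s1)CCC2`: 394 ug/mL

All three numbers come from an ADME assay on HepG2 cells (Homo sapiens) for cytotoxicity, read by MTT assay, with a stated time of 72 h; on this read-out lower numbers stand for higher toxicity in this test and higher numbers for lower toxicity in this test. Compound 3 at 394 ug/mL lies within the usual scatter of compound 2 at 431 ug/mL, and the two stand clearly apart from compound 1 at 93.7 ug/mL.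

The next compound to be tested is compound 4 `C(=C/c1ccccc1)\C=N\c1sc2c(c1-c1nc3ccccc3s1)CCC2`. It has 2-phenylethenyl in place of 2-fluorophenyl on a carbon with a double bond to nitrogen. Both groups hold one six-membered aromatic ring of carbon only.

Among the compounds with values here, one measured step bears on this change, since it swaps groups at the same place: a 1.1-fold lower number from compound 2 to compound 3 (0.04 log units; within the scatter). Within the data shown here, that step is small, but it is the only one available, and no measured compound carries 2-phenylethenyl, so the forecast remains uncertain. Given the size of that single step, no change beyond the scatter is expected in this assay, in either direction. The expected result is a 1.1-fold lower number from compound 3 to compound 4 (0.03 log units; within the scatter). For compound 4 the estimated value is 370 ug/mL, with an expected range from 190 ug/mL to 640 ug/mL.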

Compound 4, half-maximal cytotoxic concentration: 215 ug/mL
Compound 4: middle estimate off by 1.7-fold (0.24 log units), on the high side; the range from low to high includes it.
By their numbers in this assay, from the lowest: compound 1; then compounds 4, 3 and 2 (each within the scatter of the next).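

At this place, on a carbon with a double bond to nitrogen, the set now goes beyond phenyl rings joined directly to that carbon: 2-phenylethenyl brings a double bond outside aromatic rings, and it carries neither the fluorine of compound 3 nor the chlorine of compound 2. In this assay the swap gives a 1.8-fold lower number from compound 3 to compound 4 (0.26 log units; within the scatter) and, measured against the 4-chlorophenyl compound, a 2.0-fold lower number from compound 2 to compound 4 (0.30 log units; within the scatter), so both steps stay within the scatter and these three groups cannot be told apart at this place in this test. The data offer no measurement that could explain these numbers.

Going by these compounds, all three groups hold one six-membered aromatic ring of carbon only and have no hydrogen-bond donors or acceptors, so it remains open whether a carboxylic acid or a longer carbon chain without a ring, placed on the same carbon, would move the number beyond the scatter. Compound 1 differs from compound 4 in more than one place, so the compounds shown do not tell which of those differences goes with its number.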